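The compounds below may be only part of what the source reports. "The series", "measured", "known", "first", "only" and "open" are said of these compounds alone.

Measured compounds:
- compound 1, `C[C@@H]1CN(c2cc(NS(=O)(=O)c3ccc(-c4ccccn4)s3)ccc2C#N)C[C@H](C)N1`: 631 nM
- compound 2, `COc1ccc(N2C[C@@H](C)N[C@@H](C)C2)cc1NS(=O)(=O)c1ccc(-c2cc(Cl)ccc2F)cc1`: 0.501 nM

In a functional assay for agonist activity at growth hormone secretagogue receptor type 1 (Homo sapiens), read by FLIPR (on this read-out lower numbers stand for an effect already at smaller amounts and higher numbers for an effect only at larger amounts of compound), compound 1 gives 631 nM and compound 2 gives 0.501 nM, so compound 2 stands at the lowest of the two numbers, with compound 1 a good way higher and beyond the scatter. Compound 3, `COc1ccc(N2C[C@@H](C)N[C@@H](C)C2)cc1NS(=O)(=O)c1ccc(Oc2ccccc2)cc1`, is not yet measured; it differs from compound 2 by phenoxy in place of 5-chloro-2-fluorophenyl on an aromatic carbon, set on an aromatic carbon para to a large group. Going by the values given here, with no comparable step among the measured compounds, the step of a 6.0-fold higher number from compound 2 to compound 3 (0.78 log units; beyond the scatter) is expected to be modest and upward. Compound 3 is therefore estimated at 3 nM, within 0.5 nM to 30 nM.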

Compound 3, half-maximal effective concentration: 63.1 nM
Beside the measured number, compound 3's estimate is 21-fold (1.32 log units) below it; measured number above the stated range.
By their numbers in this assay, from the lowest: compound 2; then compound 3; then compound 1.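

In this assay, phenoxy in place of 5-chloro-2-fluorophenyl gives a 130-fold higher number from compound 2 to compound 3 (2.10 log units; beyond the scatter), so a single change at this aromatic carbon moves the number strongly. Both groups hold one six-membered aromatic ring of carbon only, so having such a ring at this place does not by itself preserve the low number of compound 2. The compounds shown leave open whether the oxygen link or the loss of chlorine and fluorine matters more; an unsubstituted phenyl or a 5-chloro-2-fluorophenoxy group would separate the two. No supporting measurement bears on what lies behind this step.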